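Selenium Returns: A Benzylselanyl Analogue of Compound 2

The compounds below may be only part of what the source reports. "The series", "measured", "known", "first", "only" and "open" are said of these compounds alone.

Compound 1 `C[Se]/C(=N\C(=O)c1cnc2ccccc2c1)NC(=O)c1cnc2ccccc2c1`: 8030 nM
Compound 2 `CS/C(=N\C(=O)c1cnc2ccccc2c1)NC(=O)c1cnc2ccccc2c1`: > 100000 nM

In a functional assay on MCF7 cells (Homo sapiens) for cytotoxicity, read by MTT assay, with a stated time of 72 h (on this read-out lower numbers stand for stronger inhibition of growth and higher numbers for weaker inhibition of growth), compound 1 gives 8030 nM. Compound 2 sits at the limit of > 100000 nM in this assay, at which 1 of the 2 values shown sits, so for compound 2 the value > 100000 nM is a limit rather than a number. The step of an at least 12-fold higher number from compound 1 to compound 2 (1.09 log units; beyond the scatter) shows that swapping selenium for sulfur weakened compound 2 sharply. Compound 3 `O=C(/N=C(/NC(=O)c1cnc2ccccc2c1)[Se]Cc1ccccc1)c1cnc2ccccc2c1` carries the change (a group of 8 heavy atoms (7 carbon, 1 selenium; one six-membered aromatic ring of carbon only) in place of a group of 2 heavy atoms (1 carbon, 1 sulfur; no ring), on a carbon with a double bond to nitrogen), bringing selenium back together with the benzyl group. The step from compound 1 to compound 2 bears on this, so a return toward the range of compound 1 is expected, and an at least 11-fold lower number from compound 2 to compound 3 (1.04 log units; beyond the scatter) is estimated. Compound 3 is expected at 9000 nM, between 2500 nM and 45000 nM.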

Compound 3, concentration for total growth inhibition: > 100000 nM
Compound 3: only a limit was reported; the forecaster's own chance of this, stated with the estimate: 15%; middle value at least 11-fold (1.04 log units) from the limit.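

In this assay, selenium alone does not carry the activity at this position: with selenium kept on the carbon with a double bond to nitrogen, phenyl in place of hydrogen on the saturated chain carbon bound to selenium gives an at least 12-fold higher number from compound 1 to compound 3 (1.09 log units; beyond the scatter). The step between compound 2 and compound 3 cannot be read, and compound 2 and compound 3 are each reported only as a limit: the limit of > 100000 nM in this assay, at which 2 of the 3 values shown sit.

The compounds shown leave open whether this loss goes with the phenyl ring itself or with any longer group on selenium. An ethyl group on selenium would begin to separate the two.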